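A few compounds are considered here, and "the series" means these few. Any claim that something is new, unique, unknown or untested is made for them only; others in the source may bear on it.

For the measured compounds named here, in a functional assay on NCI-H23 cells (Homo sapiens) for cytotoxicity, read by colorimetric assay (on this read-out lower numbers stand for stronger inhibition and higher numbers for weaker inhibition), compound 1 (`O=C(/C=C/c1ccc(CN2C(=O)/C(=C3\Nc4ccccc4\C3=N/O)c3cc(Cl)ccc32)cc1)NO`) gives 7 nM, the lowest of the three numbers measured so far. Compound 2 (`O=C(NO)c1ccc(CN2C(=O)/C(=C3\Nc4ccccc4\C3=N/O)c3cc(Cl)ccc32)cc1`) gives 50 nM. It carries hydroxycarbamoyl in place of 2-(hydroxycarbamoyl)ethenyl, a modest step of a 7.1-fold higher number from compound 1 to compound 2 (0.85 log units; beyond the scatter). Compound 3 (`O=C(NO)c1ccc(CN2C(=O)/C(=C3\Nc4ccccc4\C3=N/O)c3cccc(Cl)c32)cc1`) differs from compound 2 in where the chloro sits. Compound 3 gives 60 nM, which is within the usual scatter of the compound 2 value.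

Compound 4 (`O=C(/C=C/c1ccc(CN2C(=O)/C(=C3\Nc4ccccc4\C3=N/O)c3cc(Br)ccc32)cc1)NO`) keeps all of compound 1 except for one change: bromo in place of chloro on an aromatic carbon. Going by the values given here, no measured compound carries bromo, so no step here tests this swap directly, and the one measured step concerns a different part of the molecule. The closest hint is the pair of compound 2 and compound 3, which shows that the place of the chloro made no difference beyond the scatter. No step beyond the scatter is therefore expected in this assay. The expected step is a 1.1-fold higher number from compound 1 to compound 4 (0.06 log units; within the scatter). For compound 4, the estimated value is 8 nM, with an expected range from 3 nM to 20 nM.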

Compound 4, half-maximal inhibitory concentration: 9 nM
Beside the measured number, compound 4's estimate is 1.1-fold (0.05 log units) below it, and the stated range covers the measured number.
By their numbers in this assay, from the lowest: compounds 1 and 4 (each within the scatter of the next); then compounds 2 and 3 (each within the scatter of the next).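

In this assay, putting bromo in place of chloro on this aromatic carbon gives a 1.3-fold higher number from compound 1 to compound 4 (0.11 log units; within the scatter), so at this position in the core of compound 1, the two halogens cannot be told apart. The earlier compounds shown here changed only where the chloro sits, whereas here the place stays the same and the atom itself is exchanged, one heavy atom for another, with no hydrogen-bond donor or acceptor entering or leaving. No measurement shown here explains why the two halogens read alike.

Only these two halogens are shown at this position, so it remains open whether an amine, a methoxy group or a plain hydrogen there would read the same. As far as these compounds go, it is also open whether bromo would match chloro when hydroxycarbamoyl sits directly on the aromatic ring, as in compound 2.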